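This account rests on a few compounds, and the source may have more. Where it says the series, first, only, none or still open, it means among the compounds named here.

In an ADME assay on Vero cells (Chlorocebus sabaeus) for cytotoxicity, read by MTT assay (a lower number here means a stronger inhibitor, a higher number a weaker inhibitor), compound 3 `C=CCOc1cc(OC)c(C(=O)/C=C/c2ccc(O)c(OC)c2)c(OCC=C)c1` has no number to start from, its entry being "not determined" (no result reported). The move to compound 4 `C=CCOc1cc(OC)c(C(=O)/C=C/c2ccc([N+](=O)[O-])cc2)c(OCC=C)c1` is 4-nitrophenyl in place of 4-hydroxy-3-methoxyphenyl on a double-bonded chain carbon bound to a double-bonded chain carbon, with 4-nitrophenyl in place of 4-hydroxy-3-methoxyphenyl on a double-bonded chain carbon bound to a double-bonded chain carbon. The nearest measured relatives are compound 1 `C=CCOc1cc(OC)c(C(=O)/C=C/c2cccc(OC)c2)c(OCC=C)c1` at 142000 nM and compound 2 `C=CCOc1cc(OC)c(C(=O)/C=C/c2ccc(OC)cc2)c(OCC=C)c1` at 99900 nM. Going by the values given here, the only measured step, a 1.4-fold lower number from compound 1 to compound 2 (0.15 log units; within the scatter), sits at that same place and stays within the scatter. Among the compounds with values here, no measured compound carries 4-nitrophenyl, so this is weak guidance. No shift beyond the scatter from those two values is expected in this assay. The estimate for compound 4 is 100000 nM, with an expected range of 35000 nM to 220000 nM.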

Compound 4, half-maximal inhibitory concentration: 12600 nM
Beside the measured number, compound 4's estimate is 7.9-fold (0.90 log units) above it; the measured number lies below the stated range.
By their numbers in this assay, from the lowest: compound 4; then compounds 2 and 1 (each within the scatter of the next).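

In this assay, the earlier methoxy shift at this place stayed within the scatter, but the aryl group on a double-bonded chain carbon can clearly move the number. Nitro in place of methoxy on an aromatic carbon gives a 7.9-fold lower number from compound 2 to compound 4 (0.90 log units; beyond the scatter) and 4-nitrophenyl in place of 3-methoxyphenyl gives an 11-fold lower number from compound 1 to compound 4 (1.05 log units; beyond the scatter) in the same direction. No available measurement accounts for this change.

Going by these compounds, whether an amine or a carboxylic acid on that aromatic carbon would move the number in the same way remains open. Steps to or from compound 3 cannot be read.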